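Aminoamino in place of 4-methylpiperazin-1-yl: outlook for compound 4

The source may hold more compounds than are shown below. What is called first, only, known or untested is meant among the compounds shown, and "the series" means these compounds.

Of the compounds shown here, three on a shared core have been measured in an assay on isolated protein for inhibition of alkaline phosphatase, tissue-nonspecific isozyme (Homo sapiens); a lower number here means a stronger inhibitor, a higher number a weaker inhibitor. Compound 1 `CN1CCN(C(=O)c2cc(-c3ccc(Cl)cc3Cl)n[nH]2)CC1` gives 828 nM, the highest of the three numbers. Compound 2 `O=C(NCCO)c1cc(-c2cc(F)c(Cl)cc2Cl)n[nH]1` gives 100 nM and compound 3 `O=C(NCCO)c1cc(-c2ccc(F)cc2F)n[nH]1` gives 35 nM; both lie beyond the scatter from compound 1, compound 2 nearest and compound 3 furthest, so compound 1 is the weakest inhibitor of the set. Compounds 2 and 3 carry a short, donor-bearing chain on the carbonyl rather than the ring of compound 1, though they also differ from compound 1 in the substituents on the aryl ring, so the comparison is not clean.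

Compound 4 `NNC(=O)c1cc(-c2ccc(Cl)cc2Cl)n[nH]1` differs from compound 1 in one place: aminoamino in place of 4-methylpiperazin-1-yl on a carbonyl carbon. Within the data shown here, no measured pair shows this exact change, so its size is an expectation. Since compound 1 sits at 828 nM while the smaller carbonyl substituents of compounds 2 and 3 stand lower, the change is expected to lower the number, a step of a 3.3-fold lower number from compound 1 to compound 4 (0.52 log units; beyond the scatter). Compound 4 is estimated at 250 nM, with a range from 60 nM to 1000 nM.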

Compound 4, half-maximal inhibitory concentration: 44 nM
The estimate for compound 4 lay 5.7-fold (0.75 log units) above the measured number, and the stated range ends above it.
By their numbers in this assay, from the lowest: compounds 3 and 4 (each within the scatter of the next); then compound 2; then compound 1.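

In this assay the change from 4-methylpiperazin-1-yl to aminoamino on a carbonyl carbon gives a 19-fold lower number from compound 1 to compound 4 (1.27 log units; beyond the scatter) with the rest of the structure unchanged. Among these compounds, earlier comparisons changed the carbonyl substituent and the aryl substituents together, whereas this pair shows that the carbonyl substituent alone can move the number well beyond the scatter. No measurement here accounts for the step, and the pair cannot separate loss of the ring from the gain in hydrogen-bond donors.

Open, going by these compounds, is whether a simple primary amine on the carbonyl, or a piperazine without its methyl group, would give a step of similar size. Also open, on these data alone, is whether aminoamino gives a comparable step on the fluorine-bearing aryl rings of compound 2 and compound 3.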